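The source may hold more compounds than are shown below. What is called first, only, known or untested is meant among the compounds shown, and "the series" means these compounds.

Compound 1 `S=C(Nc1ccccc1)N1N=C(c2ccc(Br)cc2)CC1c1ccc2c(c1)OCCO2` gives 188000 nM in an ADME assay on L02 cells (Homo sapiens) for cytotoxicity, read by MTT assay, with a stated time of 48 h; on this read-out higher numbers stand for weaker inhibition of growth and lower numbers for stronger inhibition of growth. Compound 2 `COc1cccc(C2=NN(C(=S)Nc3ccccc3)C(c3ccc4c(c3)OCCO4)C2)c1` reaches only a limit of this assay, > 200000 nM.

Compound 1 thus holds the only number shown; the other value is a limit (the limit of > 200000 nM in this assay, at which 1 of the 2 values shown sits). Compound 3 `S=C(Nc1ccccc1)N1N=C(c2ccc(OCc3ccccc3)cc2)CC1c1ccc2c(c1)OCCO2` differs from compound 1 by benzyloxy in place of bromo on an aromatic carbon. Going by the values given here, the one measured step, an at least 1.0-fold higher number from compound 1 to compound 2 (0.02 log units; that floor lies within the scatter), exchanged a different group and stayed within the scatter, so it bears only loosely on this change. No step shown moves the read-out beyond the scatter, and none is expected here either. For compound 3 the estimated value is 170000 nM (range 60000 nM to 200000 nM), an expected step of a 1.1-fold lower number from compound 1 to compound 3 (0.04 log units; within the scatter).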

Compound 3, concentration for 50% growth inhibition: > 200000 nM
Compound 3 ended at the assay's limit (the forecaster's own chance of this, stated with the estimate: 40%); middle value at least 1.1-fold (0.07 log units) away from the limit.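

Putting benzyloxy, with its added aromatic ring, in place of bromo on this aromatic carbon gives an at least 1.0-fold higher number from compound 1 to compound 3 (0.02 log units; that floor lies within the scatter), so in this assay even this much larger group brings no stronger inhibition of growth that can be seen. The result for compound 3 is a limit, so the true size of the step cannot be read. Compound 3 joins compound 2 at that limit: the limit of > 200000 nM in this assay, at which 2 of the 3 values shown sit.

Still open, as far as these compounds go, is whether an amine or a carboxylic acid on this carbon would move the number beyond the scatter from compound 1.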